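Phenyl group swap: from compound 3 to compound 4

A few compounds are considered here, and "the series" means these few. Any claim that something is new, unique, unknown or untested is made for them only; others in the source may bear on it.

In a functional assay on A549 cells (Homo sapiens) for antiproliferative activity, read by MTT assay (on this read-out higher numbers stand for weaker inhibition and lower numbers for stronger inhibition), compound 1 `Cn1c(=O)c(=O)n(C2CCCC2)c2nc(N/N=C/c3ccc(F)c(Cl)c3)ncc21` gives 9410 nM, and compound 3 `Cn1c(=O)c(=O)n(C2CCCC2)c2nc(N/N=C/c3ccc(O)c(Br)c3)ncc21` gives 12800 nM. These two sit level: a 1.4-fold higher number from compound 1 to compound 3 (0.13 log units; within the scatter). Compound 2 `COc1ccc(/C=N/Nc2ncc3c(n2)n(C2CCCC2)c(=O)c(=O)n3C)cc1` reads > 100000 nM, which is a limit of the assay and not a number.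

Compound 3 therefore stands with compound 1, well apart from compound 2, as shown by an at least 7.8-fold lower number from compound 2 to compound 3 (0.89 log units; beyond the scatter). Among the measured compounds shown here, the 4-methoxyphenyl group of compound 2 also marks the only large measured step, an at least 10-fold higher number from compound 1 to compound 2 (1.02 log units; beyond the scatter).

Compound 4 `Cn1c(=O)c(=O)n(C2CCCC2)c2nc(N/N=C/c3ccc(F)cc3F)ncc21` carries 2,4-difluorophenyl in place of 3-bromo-4-hydroxyphenyl on a carbon with a double bond to nitrogen. For the measured compounds named here, no measured step covers this exact exchange. The closest guide is compound 1, which also bears only halogens on its phenyl ring and gives 9410 nM. Its step to compound 3 stayed within the scatter, so the working expectation in this assay is no change beyond the scatter. The expected step is a 1.1-fold higher number from compound 3 to compound 4 (0.04 log units; within the scatter). The drop to the limit seen with compound 2 keeps the upper end of the range wide. The estimate for compound 4 is 14000 nM, with an expected range of 5000 nM to 60000 nM.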

Compound 4, half-maximal inhibitory concentration: 18300 nM
Estimate against measurement, compound 4: 1.3-fold (0.12 log units) below; measured number inside the range.
By their numbers in this assay, from the lowest: compounds 1, 3 and 4 (each within the scatter of the next). At a limit, above all of these: compound 2.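

Notes on the phenyl group on the carbon with a double bond to nitrogen: in this assay, the 3-bromo-4-hydroxyphenyl group can give way to 2,4-difluorophenyl with no change beyond the scatter, a 1.4-fold higher number from compound 3 to compound 4 (0.16 log units; within the scatter), even though the hydrogen-bond donor and acceptor counted on the leaving group are absent from the entering one. The two halogen-only rings also stay within the scatter of each other, a 1.9-fold higher number from compound 1 to compound 4 (0.29 log units; within the scatter), so compounds 1, 3 and 4 read as one level despite their different substitution, and the hydroxyl and bromine of compound 3 are not needed to hold that level. Compound 2, with 4-methoxyphenyl, remains the only one set apart, an at least 5.4-fold lower number from compound 2 to compound 4 (0.73 log units; beyond the scatter), and that step is only a bound, as compound 2 reads at a limit of the assay: the limit of > 100000 nM in this assay, at which 1 of the 4 values shown sits.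

Still open, from the compounds shown here alone, is whether the gap at compound 2 belongs to the methoxy group itself or to the lack of any halogen on its ring. Also open, going by these compounds, is how a phenyl ring carrying an amine or a carboxylic acid would read at this place in this assay.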